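Dropping a Ring Methyl: From Compound 1 to Compound 3

The source may report more compounds than this note shows. Statements on the series, on what has been measured and on what is new or still open speak of the compounds shown alone.

Compound 1 `CC1CC(=O)N(CCN2CCN(c3cccc4c3OCCO4)CC2)C1=O` and compound 2 `O=C1CC2(CCCC2)CC(=O)N1CCN1CCN(c2cccc3c2OCCO3)CC1` share a core and were both measured in an ADME assay. Compound 1 gives 6.16, the lower of the two numbers; compound 2 gives 6.51, a gap beyond the scatter. Compound 3 `O=C1CCC(=O)N1CCN1CCN(c2cccc3c2OCCO3)CC1` has not yet been measured. It differs from compound 1 in one place: hydrogen in place of methyl on a saturated ring carbon. Within the data shown here, no measured pair shows this exact change, so only a small step is expected, downward if anything, and possibly within the scatter. Compound 3 is expected to give 6.05, ranging from 5.7 to 6.4. That estimate means a step of a number 0.11 log units lower from compound 1 to compound 3 (within the scatter).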

Compound 3, acid dissociation constant: 6.16
Compound 3: the middle estimate sits 0.11 log units below what was measured; measured number inside the range.
By their numbers in this assay, from the lowest: compounds 1 and 3 (each within the scatter of the next); then compound 2.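

In this assay, hydrogen in place of methyl on this saturated ring carbon gives no change at the digits printed from compound 1 to compound 3 (within the scatter) as the step, the first single-place change available in this series. At this position, then, the 3-methyl-2,5-dioxopyrrolidin-1-yl and 2,5-dioxopyrrolidin-1-yl groups cannot be told apart on this read-out. No supporting data explain this result. This single step says little about groups other than methyl on that ring carbon. Going by these compounds, whether an amine, a carboxylic acid or a longer chain there would shift the number remains open.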